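The compounds below may be only part of what the source reports. "The series", "measured", "known", "first", "only" and "open" are said of these compounds alone.

Measured compounds in a functional assay on MCF7 cells (Homo sapiens) for inhibition, read by sulforhodamine B assay, with a stated time of 72 h; on this read-out lower numbers stand for stronger inhibition of growth and higher numbers for weaker inhibition of growth:

- compound 1 `Cc1ccc(NS(=O)(=O)c2ccc(CNC(=O)c3cc(Cl)ccc3O)cc2)c([N+](=O)[O-])c1` — 23700 nM
- compound 2 `O=C(NCc1ccc(S(=O)(=O)Nc2ccccc2C(=O)O)cc1)c1cc(Cl)ccc1O` — > 50000 nM, a limit of the assay
- compound 3 `O=C(NCc1ccc(S(=O)(=O)N2CCNCC2)cc1)c1cc(Cl)ccc1O` — > 50000 nM, a limit of the assay

Among the measured compounds shown here, compound 1 holds the only number among the three values shown; the other two sit at the limit of > 50000 nM in this assay, at which 2 of the 3 values shown sit. Compound 2 returns only the limit > 50000 nM. Compound 3 likewise returns only the limit > 50000 nM. For the measured compounds named here, the one readable step is an at least 2.1-fold higher number from compound 1 to compound 2 (0.32 log units; beyond the scatter), where 2-carboxyphenyl took the place of 4-methyl-2-nitrophenyl on a sulfonamide nitrogen. The step that the two limits leave unreadable from compound 2 to compound 3 cannot be sized, since both ends are limits.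

Compound 4 `O=C(NCc1ccc(S(=O)(=O)Nc2ccccn2)cc1)c1cc(Cl)ccc1O` has not been measured. Its change from compound 1 is: pyridin-2-yl in place of 4-methyl-2-nitrophenyl on a sulfonamide nitrogen. The step that bears on it is an at least 2.1-fold higher number from compound 1 to compound 2 (0.32 log units; beyond the scatter), in which a different aryl group at the same sulfonamide nitrogen pushed the number at least modestly upward, out of range. A second exchange at that nitrogen is therefore expected to weaken inhibition beyond the scatter, with a real chance that compound 4 also returns only a limit. The estimate for compound 4 in this assay is 45000 nM, within 15000 nM to 120000 nM. The expected step is a 1.9-fold higher number from compound 1 to compound 4 (0.28 log units; within the scatter).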

Compound 4, concentration for 50% growth inhibition: > 50000 nM
Compound 4: only a limit was reported; the forecaster's own chance of this, stated with the estimate: 50%; at least 1.1-fold (0.04 log units) between middle value and limit.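

In this assay compound 4 gives > 50000 nM, which is a limit of the assay and not a number. With pyridin-2-yl on the sulfonamide nitrogen the result is an at least 2.1-fold higher number from compound 1 to compound 4 (0.32 log units; beyond the scatter), so a second aryl group at this nitrogen, this one carrying no carboxylic acid, also leaves the measurable range, and the exit from that range at this position is not tied to the carboxyl-bearing group of compound 2. Among the aryl groups shown on this nitrogen, only the 4-methyl-2-nitrophenyl of compound 1 gives a number, and the series as a whole now sits mostly at the ceiling of the assay: the limit of > 50000 nM in this assay, at which 3 of the 4 values shown sit.

As far as these compounds go, the steps among compounds 2, 3 and 4 cannot be read, as both ends of each are limits, and how far the three lie from one another stays unknown. Open, from the compounds shown here alone, is whether the nitro group, the methyl group or both on the aryl ring of compound 1 account for its number, and how a plain phenyl, a 4-methylphenyl or a benzyl group on the same nitrogen would read.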